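Side-chain swap at the amide-bearing carbon, compound 3 to compound 4

The compounds below may be only part of what the source reports. "The series", "measured", "known", "first", "only" and "open" are said of these compounds alone.

Three compounds share one core and differ only in the amino-acid side chain. Compound 1 `Cc1ncc([N+](=O)[O-])n1CCOC(=O)c1cc(NC(=O)C(C)NC(=O)OCc2ccccc2)ccc1O` gives 44.8% in a functional assay on the whole organism (strain Wistar) for inhibition, with Rattus norvegicus as the target, read by paw edema, with stated times of 1 h and 3 h, at a dose of 10 mg/kg by the intraperitoneal route; on this read-out lower numbers stand for less inhibition and higher numbers for more inhibition at the one dose given (going by the name of the read-out). Compound 2 `Cc1ncc([N+](=O)[O-])n1CCOC(=O)c1cc(NC(=O)[C@H](C)NC(=O)OCc2ccccc2)ccc1O` gives 37.1% in this assay, and the step of a number 7.7 percentage points lower from compound 1 to compound 2 (within the scatter) rests only on (the fact that one of compounds 1 and 2 is drawn with a defined configuration and the other without, at the place where they differ). Compound 3 `Cc1ncc([N+](=O)[O-])n1CCOC(=O)c1cc(NC(=O)[C@H](CCCCN)NC(=O)OCc2ccccc2)ccc1O` gives 36.9% in this assay; the step of a number 0.2 percentage points lower from compound 2 to compound 3 (within the scatter) is small. Compound 3 thus sits at the low end of the three numbers, yet compound 2 and compound 1 both lie within the scatter of it, so no ordering among them can be read.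

Compound 4 `Cc1ncc([N+](=O)[O-])n1CCOC(=O)c1cc(NC(=O)[C@@H](NC(=O)OCc2ccccc2)C(C)C)ccc1O` carries the change (isopropyl in place of 4-aminobutyl on a saturated chain carbon bound to an amide-type nitrogen and a carbonyl carbon). Within the data shown here, the one measured step that touches the same chain carbon, a number 0.2 percentage points lower from compound 2 to compound 3 (within the scatter), did not move the read-out beyond the scatter, and the stereo step a number 7.7 percentage points lower from compound 1 to compound 2 (within the scatter) likewise stayed inside it. The expectation for compound 4 is therefore a step of a number 1.1 percentage points higher from compound 3 to compound 4 (within the scatter) that stays within the scatter. Compound 4 is estimated at 38% in this assay, within a range from 27% to 49%.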

Compound 4, a percentage reported as inhibition, in the whole organism at one dose (the size of the read-out at that dose, not a potency): 61.5%
Beside the measured number, compound 4's estimate is 23.5 percentage points below it; measured number outside the range, above it.
By their numbers in this assay, from the lowest: compounds 3, 2 and 1 (each within the scatter of the next); then compound 4.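

In this assay, among these compounds, the saturated chain carbon bound to an amide-type nitrogen and a carbonyl carbon now proves able to move the read-out beyond the scatter, which no earlier step showed: isopropyl in place of 4-aminobutyl gives a number 24.6 percentage points higher from compound 3 to compound 4 (beyond the scatter), and isopropyl in place of methyl gives a number 24.4 percentage points higher from compound 2 to compound 4 (beyond the scatter), so the change holds against both earlier side chains. Methyl and 4-aminobutyl lie within the scatter of each other, so among these three groups only isopropyl stands apart. Heavy-atom count alone does not order the three groups, since isopropyl, with its 3 heavy atoms, stands apart from both the smaller methyl and the larger 4-aminobutyl.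

As far as these compounds go, how an isobutyl chain or a carboxylic acid side chain at this carbon would read remains open. Nothing in the data shown bears on why isopropyl changes the read-out.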